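Vinyl to chloromethyl: compound 3 to compound 4

This account rests on a few compounds, and the source may have more. Where it says the series, first, only, none or still open, it means among the compounds named here.

Values in a functional assay on A-375 cells (Homo sapiens) for cytotoxicity, read by MTT assay; a lower number here means a stronger inhibitor, a higher number a weaker inhibitor:
- compound 1 `COc1ccc(/C=C/C(=O)c2ccc(OC)c3c2OC(C)(C)C=C3)cc1OCC=C(C)C`: > 10000 nM, a limit of the assay
- compound 2 `CCC(=O)Oc1cc(/C=C/C(=O)c2ccc(OC)c3c2OC(C)(C)C=C3)ccc1OC`: 240 nM
- compound 3 `C=CC(=O)Oc1cc(/C=C/C(=O)c2ccc(OC)c3c2OC(C)(C)C=C3)ccc1OC`: 390 nM

Within the data shown here, compound 3 stands at 390 nM, level with its only numerical neighbour: a 1.6-fold higher number from compound 2 to compound 3 (0.21 log units; within the scatter). The large steps, an at least 41-fold lower number from compound 1 to compound 2 (1.61 log units; beyond the scatter) and an at least 25-fold lower number from compound 1 to compound 3 (1.40 log units; beyond the scatter), both start from a limit and replace 3-methylbut-2-en-1-yl on the oxygen, a change not made here. Compound 4 `COc1ccc(/C=C/C(=O)c2ccc(OC)c3c2OC(C)(C)C=C3)cc1OC(=O)CCl` differs from compound 3 as follows: chloromethyl in place of vinyl on a carbonyl carbon. Among the measured compounds shown here, this places chloromethyl in place of vinyl on a carbonyl carbon, the same site as the one small step. In this assay, the expected change is therefore none beyond the scatter, in either direction: a 1.1-fold lower number from compound 3 to compound 4 (0.05 log units; within the scatter). The estimate for compound 4 is 350 nM, with an expected range of 130 nM to 900 nM.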

Compound 4, half-maximal inhibitory concentration: 450 nM
The estimate for compound 4 lay 1.3-fold (0.11 log units) below the measured number; low and high end bracket the measured number.
By their numbers in this assay, from the lowest: compounds 2, 3 and 4 (each within the scatter of the next). At a limit, above all of these: compound 1.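

Chloromethyl in place of vinyl on the carbonyl carbon gives a 1.2-fold higher number from compound 3 to compound 4 (0.06 log units; within the scatter) in this assay and chloro in place of methyl gives a 1.9-fold higher number from compound 2 to compound 4 (0.27 log units; within the scatter) so the three carbonyl groups now shown read alike at this position, with a chlorine among them. The step of an at least 22-fold lower number from compound 1 to compound 4 (1.34 log units; beyond the scatter) is the third large one away from 3-methylbut-2-en-1-yl on that oxygen. Compound 1 stands at a limit of the assay: the limit of > 10000 nM in this assay, at which 1 of the 4 values shown sits.

Open, as far as these compounds go, is whether an amine or a longer chain on this carbonyl carbon stays level with these three.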